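Cytotoxicity notes: from compound 1 to compound 4

This account rests on a few compounds, and the source may have more. Where it says the series, first, only, none or still open, it means among the compounds named here.

- compound 1 `O=C(COc1cccc2ccccc12)N/N=C/c1ccccc1O`: 5.19 ug/mL
- compound 2 `COc1cc(/C=N/NC(=O)COc2cccc3ccccc23)cc(OC)c1O`: 16.3 ug/mL
- compound 3 `O=C(COc1cccc2ccccc12)N/N=C/c1ccccc1[N+](=O)[O-]`: 12.2 ug/mL

These values come from an ADME assay on MT4 cells (Homo sapiens) for cytotoxicity, read by MTT assay, with a stated time of 4 days (on this read-out higher numbers stand for lower toxicity in this test and lower numbers for higher toxicity in this test), where compound 1 stands lowest of the three numbers. Compound 4 `Cc1ccc(/C=N/NC(=O)COc2cccc3ccccc23)cc1` is still unmeasured. Its difference from compound 1 is 4-methylphenyl in place of 2-hydroxyphenyl on a carbon with a double bond to nitrogen.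

Within the data shown here, one measured step bears on this change: a 2.4-fold higher number from compound 1 to compound 3 (0.37 log units; beyond the scatter). It is a modest step, with nitro in place of hydroxy on an aromatic carbon. Compound 2 also carries a hydroxy group and gives 16.3 ug/mL, so the data do not tie a higher number to the loss of hydroxy alone. Among the measured compounds shown here, a single step is thin support, and no measured step introduces methyl. A modest rise in this assay is therefore expected, of about the size seen with the nitro change.

The estimated step is a 2.3-fold higher number from compound 1 to compound 4 (0.36 log units; beyond the scatter). The expected value for compound 4 is 12 ug/mL, with an estimated range from 5 ug/mL to 28 ug/mL.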

Compound 4, half-maximal cytotoxic concentration: 83.9 ug/mL
Beside the measured number, compound 4's estimate is 7.0-fold (0.84 log units) below it; the whole stated range lies below it.
By their numbers in this assay, from the lowest: compound 1; then compounds 3 and 2 (each within the scatter of the next); then compound 4.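

Among these compounds, the change to 4-methylphenyl on a carbon with a double bond to nitrogen gives a 16-fold higher number from compound 1 to compound 4 (1.21 log units; beyond the scatter) in this assay, a large step where a 2.4-fold higher number from compound 1 to compound 3 (0.37 log units; beyond the scatter) was only modest, so this position can shift the number much further than the earlier compounds showed. The step swaps the substituent and its place on the aromatic ring at once: 2-hydroxyphenyl carries 1 hydrogen-bond donor and 1 hydrogen-bond acceptor, 4-methylphenyl carries 0 of each, and the step alone cannot divide its size among these differences. Nothing measured here accounts for the size of this step.

As far as these compounds go, whether the higher number follows the loss of hydroxy, the presence of methyl or the new ring place remains open, and an unsubstituted phenyl would help to separate them. Also open, from the compounds shown here alone, is whether an amine or a carboxylic acid in place of that methyl would keep the number this high.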